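From 6-chloropyridin-2-yl to 3-chloropyridin-2-yl: compound 4

The source may hold more compounds than are shown below. What is called first, only, known or untested is meant among the compounds shown, and "the series" means these compounds.

Of the compounds shown here, three have been measured in a functional assay on HeLa cells (Homo sapiens) for inhibition, read by MTT assay, with a stated time of 72 h; a higher number here means a weaker inhibitor, a lower number a stronger inhibitor. Compound 1 `Cc1noc(C)c1-c1cnc(N)c(Oc2ccc(C(=O)Nc3cccc(Cl)n3)cc2)n1` gives 25500 nM, compound 2 `Cc1noc(C)c1-c1cnc(N)c(Oc2ccc(C(=O)Nc3ncccc3Cl)cc2)n1` gives 31900 nM, and compound 3 `Cn1cc(-c2cnc(N)c(Oc3ccc(C(=O)Nc4cccc(Cl)n4)cc3)n2)cn1` gives 38200 nM. Compound 3 has the highest of the three numbers, yet the gap to its nearest neighbour, compound 2, and the gap to its furthest neighbour, compound 1, both lie within the scatter, so the three cannot be put into any order.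

Compound 4 `Cn1cc(-c2cnc(N)c(Oc3ccc(C(=O)Nc4ncccc4Cl)cc3)n2)cn1` has not been measured. It differs from compound 3 in a single place: 3-chloropyridin-2-yl in place of 6-chloropyridin-2-yl on an amide-type nitrogen.

This same exchange has been seen once before, from compound 1 to compound 2, where it gave a 1.3-fold higher number from compound 1 to compound 2 (0.10 log units; within the scatter). The other measured step, a 1.5-fold higher number from compound 1 to compound 3 (0.18 log units; within the scatter), concerns the group on the aromatic carbon, which compound 3 and compound 4 share, so it does not bear on the present change. Because of a 1.3-fold higher number from compound 1 to compound 2 (0.10 log units; within the scatter) no step beyond the scatter is expected here. The step from compound 3 to compound 4 is therefore estimated as a 1.2-fold higher number from compound 3 to compound 4 (0.07 log units; within the scatter). Compound 4 is expected to give 45000 nM in this assay, with a range from 20000 nM to 100000 nM, and with these already high numbers a result reported only as a limit cannot be ruled out.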

Compound 4, half-maximal inhibitory concentration: 36100 nM
For compound 4 the middle estimate is 1.2-fold (0.10 log units) above the measured one, and the stated range covers the measured number.
By their numbers in this assay, from the lowest: compounds 1, 2, 4 and 3 (each within the scatter of the next).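

In this assay, within the data shown here, the exchange of 6-chloropyridin-2-yl for 3-chloropyridin-2-yl on the amide-type nitrogen now stands on a second core, where it gives a 1.1-fold lower number from compound 3 to compound 4 (0.02 log units; within the scatter), so the single earlier reading gains a partner that also stays within the scatter. The two readings agree: the same change on two cores in this assay, a 1.3-fold higher number (0.10 log units; within the scatter) from compound 1 to compound 2 and a 1.1-fold lower number (0.02 log units; within the scatter) from compound 3 to compound 4, 1.3-fold (0.12 log units) apart, within the scatter of two such steps. The exchange of 3,5-dimethyl-1,2-oxazol-4-yl for 1-methyl-1H-pyrazol-4-yl on the aromatic carbon also gains a second reading, a 1.1-fold higher number from compound 2 to compound 4 (0.05 log units; within the scatter), and these two agree as well: the same change on two cores in this assay, a 1.5-fold higher number (0.18 log units; within the scatter) from compound 1 to compound 3 and a 1.1-fold higher number (0.05 log units; within the scatter) from compound 2 to compound 4, 1.3-fold (0.12 log units) apart, within the scatter of two such steps.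

Every group shown on the amide-type nitrogen is a chloropyridin-2-yl, and every group shown on the aromatic carbon is an aromatic five-membered ring, so it remains open whether any change at either place can produce a step beyond the scatter. Also open, from the compounds shown here alone, is what this assay would give with an amine or a carboxylic acid in place of the chlorine on the pyridin-2-yl group, or with morpholin-4-yl on the aromatic carbon.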